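Pyridinyl Ether Variant of a Metabotropic Glutamate Receptor Modulator

This account rests on a few compounds, and the source may have more. Where it says the series, first, only, none or still open, it means among the compounds named here.

Measured compounds:
compound 1, `O=C1c2cc(COc3ccccc3)nn2CCN1c1ccc(F)cc1F`, 101%
compound 2, `Cc1ccc(N2CCn3nc(COc4ccccc4)cc3C2=O)nc1`, 76%
compound 3, `O=C1c2cc(COc3ccccc3F)nn2CCN1c1ccc(F)cc1`, 66%

In a functional assay on HEK293 cells for positive allosteric modulation of metabotropic glutamate receptor 5 (Homo sapiens), read by calcium flux (on this read-out higher numbers stand for larger maximal responses and lower numbers for smaller maximal responses), compound 3 gives 66%, the lowest of the three numbers. Compound 2 is near it, within the scatter, while compound 1 stands well above it, beyond the scatter. Compound 4 is `O=C1c2cc(COc3ccccn3)nn2CCN1c1ccc(F)cc1`. It differs from compound 3 in one place: pyridin-2-yl in place of 2-fluorophenyl on an oxygen on a saturated carbon.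

For the measured compounds named here, the one measured step, a number 25 percentage points lower from compound 1 to compound 2 (beyond the scatter), concerns the group on the amide-type nitrogen in the ring and not the aryl ether, so it does not bear on the change to compound 4. Compound 1 and compound 3 differ in two places at once, so their gap cannot be tied to the ether alone. Nothing measured here speaks to exchanging the ring on the ether oxygen. Compound 4 is therefore expected to stay close to compound 3, with an estimated step of a number 4 percentage points higher from compound 3 to compound 4 (within the scatter) in this assay. Compound 4 is estimated at 70%, in a range from 45% to 100%.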

Compound 4, largest response reached (Emax), in percent of the reference or control that the assay uses: 68%
Compound 4: the middle estimate sits 2 percentage points above what was measured; low and high end bracket the measured number.
By their numbers in this assay, from the lowest: compounds 3, 4 and 2 (each within the scatter of the next); then compound 1.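

In this assay, the change on the ether oxygen gives a number 2 percentage points higher from compound 3 to compound 4 (within the scatter), the first step among these compounds that can be read for the group at this place. On this read-out, pyridin-2-yl and 2-fluorophenyl on an oxygen on a saturated carbon therefore cannot be told apart, so a ring of carbon only carrying a fluorine can give way to a ring with a nitrogen and no fluorine without a change beyond the scatter in the largest response reached. Nothing measured here accounts for this similarity or says what either group contributes at this position.

As far as these compounds go, it remains open how pyridin-2-yl would behave alongside the 2,4-difluorophenyl group on the amide-type nitrogen of compound 1, which stands at 101% in this assay and differs from compound 4 in more than one place. The compounds shown also leave open whether the same tolerance would extend to other groups on this oxygen, such as pyrimidin-2-yl, pyridin-3-yl or a saturated ring like cyclohexyl, and they give no view of the effect of this change on any read-out other than the maximal response.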